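This account rests on a few compounds, and the source may have more. Where it says the series, first, only, none or still open, it means among the compounds named here.

Measured so far:
- Compound 1 `COc1cccc(-c2nc3c(c(C)nn3-c3ccccc3)c(-c3ccccc3O)c2C#N)c1`: > 23000 nM (a limit)
- Compound 2 `CCc1ccc(-c2nc3c(c(C)nn3-c3ccccc3)c(-c3ccccc3I)c2C#N)cc1`: > 20000 nM (a limit)

In an ADME assay on BJ cells (Homo sapiens) for cytotoxicity, with a stated time of 72 h (a lower number here means that less compound is needed, a higher number that more compound is needed for the effect), compound 2 gives no number, only the limit > 20000 nM. Compound 1 is likewise reported only as a limit, > 23000 nM. Within the data shown here, no step between measured compounds is available. Compound 3 `CCc1ccc(-c2nc3c(c(C)nn3-c3ccccc3)c(-c3ccccc3C(F)(F)F)c2C#N)cc1` carries trifluoromethyl in place of iodo on an aromatic carbon, ortho to a large group (trifluoromethyl in place of iodo on an aromatic carbon). In this assay the expected step that the limit leaves unreadable from compound 2 to compound 3 is none beyond the scatter, and a further limit is the likeliest report. For compound 3 the estimated value is 22000 nM, with an expected range of 9000 nM to 50000 nM.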

Compound 3, half-maximal effective concentration: > 20000 nM
Compound 3: a limit, no number; the forecaster's own chance of this, stated with the estimate: 85%; the middle value lies beyond the limit too.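

In this assay compound 2 and compound 3 are both reported only as limits, and no step can be read between them. The compounds shown leave open whether trifluoromethyl in place of iodo changes the half-maximal effective concentration at all.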